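Iodo for methoxy: expected standing of compound 4

This account rests on a few compounds, and the source may have more. Where it says the series, first, only, none or still open, it means among the compounds named here.

Among the measured compounds shown here, compound 2 `COc1ccc(/C=C(/Sc2ccc(Br)cc2)C(=O)c2ccc(Br)cc2)cc1` gives 25000 nM in a functional assay on DU-145 cells (Homo sapiens) for inhibition, read by trypan blue exclusion, with a stated time of 96 h (a lower number here means a stronger inhibitor of growth, a higher number a weaker inhibitor of growth), and stands second highest of the three numbers so far, with compound 3 nearest, within the scatter, and compound 1 furthest, beyond it. Compound 3 `COc1ccc(/C=C(/Sc2ccc(Br)cc2)C(=O)c2ccc(Cl)cc2)cc1` gives 50000 nM in this assay, with a 2.0-fold higher number from compound 2 to compound 3 (0.30 log units; within the scatter); compound 1 `COc1ccc(/C=C(/SCc2ccc(Cl)cc2)C(=O)c2ccc(Br)cc2)cc1` gives 10000 nM, with a 2.5-fold higher number from compound 1 to compound 2 (0.40 log units; beyond the scatter). Compound 4 `O=C(/C(=C\c1ccc(I)cc1)Sc1ccc(Br)cc1)c1ccc(Br)cc1` differs from compound 2 by iodo in place of methoxy on an aromatic carbon. Neither measured step touches the ring that carries the methoxy group: one exchanges the group on the sulfur, the other puts chloro in place of bromo on an aromatic carbon elsewhere. For the measured compounds named here, no measured step therefore bears directly on this change, and no step beyond the scatter is expected in this assay. Compound 4 is estimated at 25000 nM, within 8000 nM to 80000 nM, the expected step being no change at the digits printed from compound 2 to compound 4 (within the scatter).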

Compound 4, concentration for 50% growth inhibition: 1000 nM
Beside the measured number, compound 4's estimate is 25-fold (1.40 log units) above it; the whole stated range lies above it.
By their numbers in this assay, from the lowest: compound 4; then compound 1; then compounds 2 and 3 (each within the scatter of the next).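

In this assay, the position held by methoxy in compound 2 proves sensitive: 4-methoxyphenyl to 4-iodophenyl gives a 25-fold lower number from compound 2 to compound 4 (1.40 log units; beyond the scatter), a larger step than either earlier change elsewhere in the series. Growth inhibition therefore depends strongly on this substituent, a dependence the earlier compounds could not reveal. No evidence on hand accounts for this step.

Open, as far as these compounds go, is whether the gain is specific to iodo or would also appear with bromo, chloro, an amine or a carboxylic acid here. Also open, from the compounds shown here alone, is whether it carries over to the 4-chlorobenzyl group on sulfur.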